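The source may hold more compounds than are shown below. What is called first, only, known or untested is meant among the compounds shown, and "the series" means these compounds.

Values in a functional assay on HeLa cells (Homo sapiens) for cytotoxicity, read by WST assay, with a stated time of 48 h; a lower number here means a stronger inhibitor, a higher number a weaker inhibitor:

compound 1 `COc1ccc([C@@H]2OC[C@H]([C@@H](O)c3ccc(OC)c(OC)c3)C[C@H]2C/C=C/c2ccc(OC)c(OC)c2)cc1`: 29200 nM
compound 2 `O[C@@H](c1ccccc1)[C@H]1CO[C@H](c2ccccc2)[C@@H](C/C=C/c2cccc(F)c2)C1`: 8380 nM
compound 3 `COc1ccc(/C=C/C[C@H]2C[C@@H]([C@@H](O)c3ccc(OC)c(OC)c3)CO[C@@H]2c2ccc(OC)c(OC)c2)cc1`: 12200 nM

Compound 2, at 8380 nM, sits within the scatter of compound 3 at 12200 nM. The value of compound 1, 29200 nM, is higher than that of compound 2, and this gap lies beyond the scatter. All three values are thus in the micromolar range, and none of the compounds shows strong cytotoxicity in this assay.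

Compound 4 `COc1ccc(/C=C/C[C@H]2C[C@@H]([C@@H](O)c3ccccc3)CO[C@@H]2c2ccccc2)cc1` has not yet been measured. It differs from compound 2 as follows: 4-methoxyphenyl in place of 3-fluorophenyl on a double-bonded chain carbon bound to a double-bonded chain carbon. In words, 4-methoxyphenyl stands in place of 3-fluorophenyl on a double-bonded chain carbon bound to a double-bonded chain carbon. For the measured compounds named here, no pair of measured compounds isolates this change. The closest evidence is compound 3, which also carries 4-methoxyphenyl at this place and gives 12200 nM, although it differs from compound 4 elsewhere. The expected 1.2-fold higher number from compound 2 to compound 4 (0.08 log units; within the scatter) is small and stays within the scatter, with no clear direction. For compound 4 the estimated value is 10000 nM, with an expected range of 4500 nM to 24000 nM.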

Compound 4, half-maximal inhibitory concentration: 8300 nM
Compound 4: the middle estimate sits 1.2-fold (0.08 log units) above what was measured; the measured number falls inside the stated range.
By their numbers in this assay, from the lowest: compounds 4, 2 and 3 (each within the scatter of the next); then compound 1.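

In this assay, for the compounds shown here, the change to 4-methoxyphenyl in place of 3-fluorophenyl on a double-bonded chain carbon bound to a double-bonded chain carbon gives a 1.0-fold lower number from compound 2 to compound 4 (0.00 log units; within the scatter), and this is the first step that isolates a single place. With the rest of the structure held fixed, the two aryl groups are not told apart here, so this position tolerates the exchange of a fluorine-bearing ring for a methoxy-bearing one without a shift beyond the scatter. Nothing at hand gives a reason for this flat step.

Still open, from the compounds shown here alone, is whether the same exchange stays flat on the more heavily methoxylated core of compound 3. Going by these compounds, it is also open whether an amine or a carboxylic acid on this aryl ring, or a longer chain leading to it, would move the number at all.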